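A few compounds are considered here, and "the series" means these few. Any claim that something is new, unique, unknown or untested is made for them only; others in the source may bear on it.

Compound 2 `COc1ccc(CN2C(=O)C(=O)c3cc(-c4ccc(C)cc4)ccc32)cc1` stands at the far end of the numbers available: in a functional assay on HepG2 cells (Homo sapiens) for antiproliferative activity, read by MTT assay, with a stated time of 48 h (a higher number here means a weaker inhibitor, a lower number a stronger inhibitor), compound 2 gives > 10000 nM, which is a limit of the assay rather than a number (the limit of > 10000 nM in this assay, at which 1 of the 2 values shown sits). Among the compounds with values here, the only other measured compound is compound 1 `COc1ccc(CN2C(=O)C(=O)c3cc(-c4ccc(OC)cc4)ccc32)cc1`, and in this assay compound 1 gives 50 nM. Within the data shown here, the one measured step, an at least 200-fold higher number from compound 1 to compound 2 (2.30 log units; beyond the scatter), is large and runs beyond the scatter, so replacing the methoxy with a methyl is what removes the activity here. Compound 3 `COc1ccc(CN2C(=O)C(=O)c3cc(-c4ccc(OC(C)C)cc4)ccc32)cc1` differs from compound 2 by isopropoxy in place of methyl on an aromatic carbon. This change brings back an alkoxy oxygen on the same aromatic carbon, the kind of group whose loss is measured in an at least 200-fold higher number from compound 1 to compound 2 (2.30 log units; beyond the scatter), so a large step in this assay is expected for compound 3 an at least 66-fold lower number from compound 2 to compound 3 (1.82 log units; beyond the scatter), toward a lower number. Compound 3 is estimated at 150 nM, within 30 nM to 1500 nM.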

Compound 3, half-maximal inhibitory concentration: > 10000 nM
Compound 3 gave a limit, no number (the forecaster's own chance of this, stated with the estimate: 15%); at least 66-fold (1.82 log units) between middle value and limit.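

In this assay, putting an isopropyl in place of the methyl on the oxygen gives an at least 200-fold higher number from compound 1 to compound 3 (2.30 log units; beyond the scatter). An alkoxy oxygen on this aromatic carbon is therefore not enough on its own to keep the activity, and among the three compounds only the methoxy of compound 1 gives a measurable value. Compound 3 gives only a limit of the assay, as compound 2 does, so the step joining these two cannot be read and neither can be placed ahead of the other: the limit of > 10000 nM in this assay, at which 2 of the 3 values shown sit.

The compounds shown leave open whether an ethoxy on the same aromatic carbon would keep a value near that of compound 1, which gives 50 nM. They also leave open how a hydroxy or an amine would fare there.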